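The source may hold more compounds than are shown below. What is called first, only, known or untested is meant among the compounds shown, and "the series" means these compounds.

Compound 1 `COc1cccc(OC)c1OCCNCCOc1ccccc1OCc1ccc(Cl)cc1`: 9.11
Compound 2 `COc1cccc(OC)c1OCCNCCOc1ccccc1OCc1cccc([N+](=O)[O-])c1`: 9.28

Among the measured compounds shown here, in a functional assay on thoracic aorta for antagonist activity at Alpha-1D adrenergic receptor (Rattus norvegicus) (a higher number here means a more potent compound, by a factor of ten per unit of this negative logarithm, a lower number a less potent compound), compound 2 gives 9.28, and its only neighbour is compound 1, separated by a number 0.17 log units higher from compound 1 to compound 2 (within the scatter), so the two values lie within the scatter of each other. Compound 3 `COc1cccc(OC)c1OCCNCCOc1ccccc1OCc1ccc([N+](=O)[O-])cc1` differs from compound 2 by 4-nitrophenyl in place of 3-nitrophenyl on a saturated chain carbon bound to an oxygen on an aromatic ring. For the measured compounds named here, the one step that bears on this is the change from compound 1 to compound 2, where a swap of one substituted phenyl for another gave a number 0.17 log units higher from compound 1 to compound 2 (within the scatter). A step of no more than the scatter is therefore expected, a number 0.08 log units lower from compound 2 to compound 3 (within the scatter). Compound 3 is estimated at 9.2, within 8.6 to 9.8.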

Compound 3, negative logarithm of the antagonist equilibrium constant: 9.41
Beside the measured number, compound 3's estimate is 0.21 log units below it; the range from low to high includes it.
By their numbers in this assay, from the lowest: compounds 1, 2 and 3 (each within the scatter of the next).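

In this assay, moving the nitro group around the ring makes no difference that can be read: 4-nitrophenyl in place of 3-nitrophenyl gives (a number 0.13 log units higher from compound 2 to compound 3 (within the scatter)). Nitro in place of chloro on an aromatic carbon also stays inside repeat-measurement noise (a number 0.30 log units higher from compound 1 to compound 3 (within the scatter)), so all three compounds sit together at this position. Nothing measured here offers a reason for this. Still open, going by these compounds, is whether an amine or a carboxylic acid on this ring would hold the number, and whether a longer chain between the ring and the oxygen would.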